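Benzyl on the aryl amine of compound 3: expected growth inhibition

This account rests on a few compounds, and the source may have more. Where it says the series, first, only, none or still open, it means among the compounds named here.

Compound 1 `CNc1ccc(-c2cn3c(OC)cc(OC)nc3n2)cc1`: > 100000 nM, a limit of the assay.
Compound 2 `Cc1ccn2cc(-c3ccc([N+](=O)[O-])cc3)nc2c1`: 62400 nM.
Compound 3 `Cc1ccn2cc(-c3ccc(N)cc3)nc2c1`: > 100000 nM, a limit of the assay.

All three compounds were run in a functional assay on A549 cells (Homo sapiens) for antiproliferative activity, read by MTT assay, with a stated time of 72 h; on this read-out lower numbers stand for stronger inhibition of growth and higher numbers for weaker inhibition of growth. Compound 2 gives a number, 62400 nM. Compound 3 gives only a limit of the assay, > 100000 nM. Compound 1 likewise gives only a limit, > 100000 nM. Compound 3 therefore stands at the edge of what this assay reports, together with compound 1 (the limit of > 100000 nM in this assay, at which 2 of the 3 values shown sit). Among the measured compounds shown here, the only single-point step among the measured compounds is an at least 1.6-fold higher number from compound 2 to compound 3 (0.20 log units; that floor lies within the scatter); its floor lies within the scatter, so no direction is established by it.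

Compound 4 `Cc1ccn2cc(-c3ccc(NCc4ccccc4)cc3)nc2c1` differs from compound 3 by benzyl in place of hydrogen on a nitrogen on an aromatic ring. For the measured compounds named here, no measured step concerns a change on this nitrogen; the one measured step exchanges the group on the aromatic carbon and does not bear on benzyl entering on the amine nitrogen. Going by the values given here, no size of step in this assay can therefore be derived from the measured compounds. With compound 3 sitting at the limit, compound 4 is expected to remain near the same place, with some chance that a number is reported rather than a limit. Compound 4 is estimated at 100000 nM, within 20000 nM to 500000 nM. This means an expected step of a number no higher from compound 3 to compound 4 (the limit leaves the size open).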

Compound 4, concentration for 50% growth inhibition: 5100 nM
Estimate against measurement, compound 4: 20-fold (1.29 log units) above; the measured number lies below the stated range.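

In this assay the nitrogen on the aromatic ring proves to be a place where a single change clearly moves the read-out: benzyl in place of hydrogen gives an at least 19-fold lower number from compound 3 to compound 4 (1.29 log units; beyond the scatter). Among the compounds shown here, the only step available before this, an at least 1.6-fold higher number from compound 2 to compound 3 (0.20 log units; that floor lies within the scatter), established no direction, whereas benzylamino in place of nitro on the aromatic carbon now gives a 12-fold lower number from compound 2 to compound 4 (1.09 log units; beyond the scatter), so the group carried at this place on the aryl ring does matter. As far as these compounds go, the step from the free amine can be read only as a floor, and its true size stays unknown, since the starting value is a limit of the assay and not a number: the limit of > 100000 nM in this assay, at which 2 of the 4 values shown sit.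

The compounds shown leave open whether the benzyl ring itself is needed, or whether a plain methyl, a longer chain such as phenethyl, or a benzoyl group on the same nitrogen would give a similar number. They also leave open how a chlorine or a methoxy group on the benzyl ring would shift the value of compound 4, 5100 nM.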